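A Fluorine Moved Within the Same Ring

A few compounds are considered here, and "the series" means these few. Any claim that something is new, unique, unknown or untested is made for them only; others in the source may bear on it.

Of the compounds shown here, two built on a shared core have been measured so far. Compound 1 `Nc1scc(CN2CCN(c3cccc(Cl)c3Cl)CC2)c1C(=O)c1ccc(Cl)cc1` gives 1% in a functional assay on CHO cells with adenosine receptor A1 (Homo sapiens) as the target, read by cAMP accumulation and immunoassay, with a stated time of 6 min, tested at 0.01 uM; on this read-out lower numbers stand for a stronger effect and higher numbers for a weaker effect at the one concentration tested. Compound 2 `Nc1scc(CN2CCN(c3cccc(F)c3)CC2)c1C(=O)c1ccc(Cl)cc1` gives -18% in this assay, which is the lowest of the two numbers recorded. Going by the values given here, the only step known, a number 19 percentage points lower from compound 1 to compound 2 (beyond the scatter), corresponds to 3-fluorophenyl in place of 2,3-dichlorophenyl on an amine nitrogen in a ring.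

Compound 3 `Nc1scc(CN2CCN(c3ccccc3F)CC2)c1C(=O)c1ccc(Cl)cc1` has not yet been measured. It differs from compound 2 in one place: 2-fluorophenyl in place of 3-fluorophenyl on an amine nitrogen in a ring. The two have the same atoms, joined differently. Among the compounds with values here, no measured step concerns this exchange; the single known step swaps one group for another of different composition, and so it offers little guidance for a change that merely moves a fluorine within the same ring. In the absence of a bearing step, the change is expected to bring no step beyond the scatter, so the estimated step for compound 3 is a number 6 percentage points higher from compound 2 to compound 3 (within the scatter). Compound 3 is therefore estimated at -12% in this assay, with a range from -35% to 10%.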

Compound 3, a percentage reported as activity, at one concentration (the size of the read-out at that concentration, not a potency): 2.1%
Compound 3: the middle estimate sits 14.1 percentage points below what was measured, and the stated range covers the measured number.
By their numbers in this assay, from the lowest: compound 2; then compounds 1 and 3 (each within the scatter of the next).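

The position on the amine nitrogen in a ring responds to where the fluorine stands and not only to what the group is made of: the leaving and entering groups hold the same atoms, yet in this assay 2-fluorophenyl in place of 3-fluorophenyl gives a number 20.1 percentage points higher from compound 2 to compound 3 (beyond the scatter). The other new comparison, 2-fluorophenyl in place of 2,3-dichlorophenyl, gives a number 1.1 percentage points higher from compound 1 to compound 3 (within the scatter), so the earlier step can no longer be read as the simple result of exchanging the dichlorinated group for a fluorinated one, since of the two fluorophenyl groups only 3-fluorophenyl stands apart from 2,3-dichlorophenyl. Nothing available bears on why the placement of the fluorine matters here.

The compounds shown leave open whether a 4-fluorophenyl group or a plain phenyl group on the same nitrogen would read like compound 2 or like compound 3. They also leave open whether the gap depends on fluorine itself or would persist with a chlorine or a methoxy group moved around the same ring, and a reading at one concentration gives no potency for any of them.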